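Methoxy for Methyl on a Pyrazole Aldehyde Series

This account rests on a few compounds, and the source may have more. Where it says the series, first, only, none or still open, it means among the compounds named here.

Compound 1: `COc1ccc(-c2nn(-c3ccc(Cl)cc3)cc2C=O)cc1` — 63.1%
Compound 2: `Cc1ccc(-c2nn(-c3ccc(Cl)cc3)cc2/C=N\c2ccccc2)cc1` — 40.1%

Of the compounds shown here, two have been measured in a functional assay on the whole organism (strain Wistar albino) for inhibition, with Rattus norvegicus as the target, read by paw edema, with stated times of 1 h and 2 h, at a dose of 0.32 mmol/kg by the intraperitoneal route; on this read-out higher numbers stand for more inhibition at the one dose given (going by the name of the read-out) and lower numbers for less inhibition. Compound 1 gives 63.1%, and compound 2 gives 40.1%. Going by the values given here, of the two numbers, compound 2 stands lowest; compound 1 is its only neighbour, and the gap between them is beyond the usual scatter. Compound 1 and compound 2 differ in more than one place, so no single step can be read from that pair; their two values simply show that compound 1 inhibits more at the dose given.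

Compound 3, `COc1ccc(-c2nn(-c3ccc(Cl)cc3)cc2/C=N\c2ccccc2)cc1`, has not yet been measured. It differs from compound 2 by methoxy in place of methyl on an aromatic carbon. Among the compounds with values here, no measured pair isolates this change, and the only other compound, compound 1, carries the same methoxy group alongside a different substituent on the core. A step is therefore expected in this assay for compound 3 that is small and upward, of the order of the scatter or a little beyond it, from compound 2, namely a number 7.9 percentage points higher from compound 2 to compound 3 (within the scatter). Compound 3 is accordingly estimated at 48%, within a range from 35% to 62%.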

Compound 3, a percentage reported as inhibition, in the whole organism at one dose (the size of the read-out at that dose, not a potency): 57.2%
Beside the measured number, compound 3's estimate is 9.2 percentage points below it; the range from low to high includes it.
By their numbers in this assay, from the lowest: compound 2; then compounds 3 and 1 (each within the scatter of the next).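

In this assay, going by these compounds alone, the change from 4-methylphenyl to 4-methoxyphenyl gives a number 17.1 percentage points higher from compound 2 to compound 3 (beyond the scatter), the first step that isolates a single place, and it shows that this aromatic carbon, para to a large group, responds to methoxy in place of methyl, if only modestly. With the methoxy group held constant, exchanging the small group on the shared core for the larger group carrying a six-membered aromatic ring of carbon only gives a number 5.9 percentage points lower from compound 1 to compound 3 (within the scatter), so this exchange does not separate the two compounds on this read-out. No supporting measurement bears on why the methoxy step arises.

The compounds shown leave open whether a hydroxyl, a chlorine or a longer ether chain such as ethoxy at this position would match methoxy or fall back towards methyl. They also leave open whether the exchange of methyl for methoxy would give a step of similar size when the core carries the smaller group found in compound 1.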